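This account rests on a few compounds, and the source may have more. Where it says the series, first, only, none or still open, it means among the compounds named here.

Measured compounds in an assay on isolated protein for activation of cGMP-dependent protein kinase 1 (Homo sapiens), read by ADP-Glo, with stated times of 120 min and 40 min; on this read-out higher numbers stand for an effect only at larger amounts of compound and lower numbers for an effect already at smaller amounts:
compound 1 `OC[C@@H](O[C@H]1CCCN(Cc2ncc[nH]2)[C@H]1c1ccccc1)c1cc(Cl)cc(Cl)c1` gives 7000 nM; compound 2 `Clc1cc(Cl)cc(CO[C@H]2CCCN(Cc3ncc[nH]3)[C@H]2c2ccccc2)c1` gives 47000 nM.

Compound 1 stands at the lowest of the two numbers in this assay, and its nearest neighbour is compound 2, separated by a 6.7-fold higher number from compound 1 to compound 2 (0.83 log units; beyond the scatter). That step was brought about by a hydrogen in place of the hydroxymethyl on the saturated chain carbon bound to an aromatic carbon and an oxygen on a saturated carbon. The unmeasured compound 3 `OC[C@@H](O[C@H]1CCCN(Cc2ccccc2Cc2nnco2)[C@H]1c1ccccc1)c1cc(Cl)cc(Cl)c1` keeps that hydroxymethyl and keeps the shared core of compound 1; it differs from compound 1 only at the group on the saturated chain carbon bound to the amine nitrogen in the ring, where (a group of 12 heavy atoms (9 carbon, 2 nitrogen, 1 oxygen; one five-membered aromatic ring with 3 hetero atoms, one six-membered aromatic ring of carbon only) in place of a group of 5 heavy atoms (3 carbon, 2 nitrogen; one five-membered aromatic ring with 2 hetero atoms), on a saturated chain carbon bound to an amine nitrogen in a ring). Among the compounds with values here, no measured step touches that position: the single step from compound 1 to compound 2 changes a different part of the molecule and so gives no guide to the direction or size of the change in this assay. Within the data shown here, with no step that bears on it, the expectation for compound 3 is that this assay gives a number close to that of compound 1, with a wide range in either direction; the estimated step is no change at the digits printed from compound 1 to compound 3 (within the scatter). Compound 3 is estimated at 7000 nM, from 1500 nM to 35000 nM.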

Compound 3, half-maximal effective concentration: 3700 nM
Beside the measured number, compound 3's estimate is 1.9-fold (0.28 log units) above it; the measured number falls inside the stated range.
By their numbers in this assay, from the lowest: compounds 3 and 1 (each within the scatter of the next); then compound 2.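

In this assay, within the data shown here, the position on a saturated chain carbon bound to an amine nitrogen in a ring accepts a much larger group without leaving the scatter: replacing 1H-imidazol-2-yl with the group of 12 heavy atoms gives a 1.9-fold lower number from compound 1 to compound 3 (0.28 log units; within the scatter), a step the earlier compounds could not show, since they differ only at the hydroxymethyl. The entering group has 0 hydrogen-bond donors and 3 hydrogen-bond acceptors, against 1 of each in the group that leaves, so a hydrogen-bond donor in this group is not required for a value in this range, although these changes arrive together and cannot be separated here. No measurement shown here explains why the two compounds read alike.

Going by these compounds, it remains open whether the six-membered aromatic ring of carbon only would read the same alone, or with a carboxylic acid or an amine in place of the five-membered aromatic ring with 3 hetero atoms. On these data alone, it is also open whether hydrogen in place of the hydroxymethyl would cost as much on compound 3 as in the step of a 6.7-fold higher number from compound 1 to compound 2 (0.83 log units; beyond the scatter).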